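Quinazolinyl-thioacetanilide series: step to the nitrophenylamino analogue

The compounds below may be only part of what the source reports. "The series", "measured", "known", "first", "only" and "open" are said of these compounds alone.

Measured compounds and their values in a functional assay on MDA-MB-231 cells (Homo sapiens) for inhibition, read by MTT assay, with a stated time of 72 h; on this read-out lower numbers stand for stronger inhibition and higher numbers for weaker inhibition:
compound 1 `O=C(CSc1nc(Nc2ccccc2)c2ccccc2n1)Nc1cccc(Br)c1` — 17500 nM
compound 2 `CCc1cccc(NC(=O)CSc2nc(Nc3ccccc3)c3ccccc3n2)c1` — 12400 nM
compound 3 `C=CC(=O)Nc1cccc(NC(=O)CSc2nc(Nc3ccccc3Cl)c3ccccc3n2)c1` — 12700 nM

All three numbers lie close together. Compound 3 holds the second highest value of the three; the nearest is compound 2 and the furthest is compound 1, and both gaps are within the scatter. For the measured compounds named here, the one measured step that changes a single place, a 1.4-fold lower number from compound 1 to compound 2 (0.15 log units; within the scatter), concerns the aryl on the amide side and is itself within the scatter.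

Compound 4 `C=CC(=O)Nc1cccc(NC(=O)CSc2nc(Nc3cccc([N+](=O)[O-])c3)c3ccccc3n2)c1` is not yet measured. It differs from compound 3 in the change (3-nitrophenyl in place of 2-chlorophenyl on a nitrogen on an aromatic ring). Going by the values given here, no measured step touches this position: the only step available, from compound 1 to compound 2, varies the other aryl and gives no guide to the anilino side. Among the compounds with values here, with the series so flat across three compounds and the one recorded step inside the scatter, no change beyond the scatter is expected in this assay for compound 4, which corresponds to an expected step of no change at the digits printed from compound 3 to compound 4 (within the scatter).

Compound 4 is therefore estimated at 12700 nM, within a range from 5000 nM to 32000 nM.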

Compound 4, half-maximal inhibitory concentration: > 50000 nM
Compound 4 ended at the assay's limit; the forecaster's own chance of this, stated with the estimate: 10%; at least 3.9-fold (0.59 log units) between middle value and limit.
By their numbers in this assay, from the lowest: compounds 2, 3 and 1 (each within the scatter of the next). At a limit, above all of these: compound 4.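

In this assay, for the compounds shown here, the change from (2-chlorophenyl)amino to (3-nitrophenyl)amino gives an at least 3.9-fold higher number from compound 3 to compound 4 (0.59 log units; beyond the scatter) and so marks the anilino side as a position where the read-out responds beyond the scatter, whereas the only earlier step, a 1.4-fold lower number from compound 1 to compound 2 (0.15 log units; within the scatter) on the amide side, gave no such signal. On these data alone, for compound 4 the reading is a limit of the assay and not a number, so the step has a lower bound only and its full size is unknown: the limit of > 50000 nM in this assay, at which 1 of the 4 values shown sits. The step also alters two features together, the identity of the ring substituent and its printed location on the ring, and a single pair cannot separate the two.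

As far as these compounds go, whether the weaker reading follows the nitro group itself or its location stays open, and a 3-chlorophenyl or a 2-nitrophenyl on the same nitrogen would be needed to tell these apart. Also open, from the compounds shown here alone, is how far this position tolerates other groups on the same ring, such as an amine, a methoxy group or a carboxylic acid in place of the nitro group.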